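This account rests on a few compounds, and the source may have more. Where it says the series, first, only, none or still open, it means among the compounds named here.

Measured so far in a physicochemical assay for solubility, in phosphate buffer, measured as kinetic solubility; a higher number here means a more soluble compound, a lower number a less soluble compound:
- compound 1 (`CC(C)[C@@H](c1ccc(-c2ccc3cccc(F)c3c2)[nH]c1=O)[C@@H]1OC(=O)NC1=O`): 27400 nM
- compound 2 (`CC(C)[C@H](C[C@H]1OC(=O)NC1=O)c1ccc(-c2ccc3cccc(F)c3c2)[nH]c1=O`): 35400 nM
- compound 3 (`CC(C)/C(=C1\C(=O)NC(=O)N1C)c1ccc(-c2ccc3cccc(F)c3c2)[nH]c1=O`): 22500 nM

Compound 2 gives 35400 nM and that value lies within the scatter of those of compound 1 and compound 3, so the three cannot be ranked. Compound 4 (`CC(C)[C@H](C[C@H]1SC(=O)NC1=O)c1ccc(-c2ccc3cccc(F)c3c2)[nH]c1=O`) has not yet been measured. It differs from compound 2 at one place (2,4-dioxo-1,3-thiazolidin-5-yl in place of 2,4-dioxo-1,3-oxazolidin-5-yl on a saturated chain carbon, two bonds along the chain from an aromatic carbon), where 2,4-dioxo-1,3-thiazolidin-5-yl stands in place of 2,4-dioxo-1,3-oxazolidin-5-yl on a saturated chain carbon, two bonds along the chain from an aromatic carbon.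

Going by the values given here, no measured step makes this exchange, so the data offer no direct precedent. Among the compounds with values here, the one step available is a 1.3-fold higher number from compound 1 to compound 2 (0.11 log units; within the scatter) and it concerns the (2,4-dioxo-1,3-oxazolidin-5-yl)methyl group rather than the ring atoms. Compound 3 carries a different group on the shared core, and its value of 22500 nM also stays within the scatter of the value of compound 2. The three values therefore give no ground for expecting a large move, and they indicate no direction. In this assay the estimated step is a 1.2-fold lower number from compound 2 to compound 4 (0.07 log units; within the scatter) and no move beyond the scatter is expected. For compound 4 the estimated value is 30000 nM (expected range 14000 nM to 55000 nM).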

Compound 4, solubility: 31200 nM
For compound 4 the middle estimate is 1.0-fold (0.02 log units) below the measured one, within the range that was stated.
By their numbers in this assay, from the lowest: compounds 3, 1, 4 and 2 (each within the scatter of the next).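

In this assay, going by these compounds alone, 2,4-dioxo-1,3-thiazolidin-5-yl in place of 2,4-dioxo-1,3-oxazolidin-5-yl on a saturated chain carbon, two bonds along the chain from an aromatic carbon, gives a 1.1-fold lower number from compound 2 to compound 4 (0.05 log units; within the scatter) and so provides the first direct reading of this ring exchange: at this place, the assay does not separate the two rings. The wider change, which exchanges the ring and adds the methyl link together, gives a 1.1-fold higher number from compound 1 to compound 4 (0.06 log units; within the scatter) and shows that this still leaves the two compounds indistinguishable here. Nothing available bears on what lies behind these two readings.

With every step shown still inside the scatter, the compounds do not reveal any change at this position that moves the number in this assay by a readable amount. As far as these compounds go, it remains open whether a carboxylic acid or an amine in place of the ring, or a longer chain between the ring and the saturated chain carbon, would give such a step.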